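From allyl to phenyl on the shared core

The source may report more compounds than this note shows. Statements on the series, on what has been measured and on what is new or still open speak of the compounds shown alone.

Among the measured compounds shown here, in a functional assay on BV-2 cells (Mus musculus) for inhibition, read by Griess assay, with a stated time of 24 h (on this read-out higher numbers stand for weaker inhibition and lower numbers for stronger inhibition), compound 3 `C=CCc1ccc(O)c(-c2ccn(CC=C)n2)c1` gives 1200 nM, the lower of the two true numbers measured so far. In the same test, this assay, compound 2 `C=CCc1ccc(OC)c(-c2ccn(-c3ccccc3)n2)c1` gives 8920 nM, which is higher than compound 3 by more than the usual scatter. In this assay compound 1 `Oc1ccc(Br)cc1-c1ccn(-c2ccccc2)n1` returned only a limit (> 200000 nM) and no number.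

Compound 4 `C=CCc1ccc(O)c(-c2ccn(-c3ccccc3)n2)c1` is the next to be tested, with phenyl in place of allyl on an aromatic nitrogen. For the measured compounds named here, no measured pair isolates this change. Compound 2 also carries phenyl on that nitrogen and gives 8920 nM, but it differs from compound 4 elsewhere too, so it is only a loose guide. On that basis, a moderate rise in this assay is expected, meaning somewhat weaker inhibition, a little beyond the scatter. The expected change is a 2.5-fold higher number from compound 3 to compound 4 (0.40 log units; beyond the scatter). For compound 4 the estimated value is 3000 nM, with an expected range from 800 nM to 11000 nM.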

Compound 4, half-maximal inhibitory concentration: 73000 nM
Beside the measured number, compound 4's estimate is 24-fold (1.39 log units) below it, and the stated range ends below it.
By their numbers in this assay, from the lowest: compound 3; then compound 2; then compound 4. At a limit, above all of these: compound 1.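

Among the compounds shown here, on the aromatic nitrogen, phenyl in place of allyl gives a 61-fold higher number from compound 3 to compound 4 (1.78 log units; beyond the scatter) in this assay, the first direct reading of this change, and it shows that this position is far from indifferent to the group it carries. With phenyl held on that nitrogen, hydrogen in place of methyl on an oxygen on an aromatic ring gives an 8.2-fold higher number from compound 2 to compound 4 (0.91 log units; beyond the scatter), so phenyl there does not fix the number on its own and the group on that oxygen also counts. Allyl in place of bromo on an aromatic carbon gives an at least 2.7-fold lower number from compound 1 to compound 4 (0.43 log units; beyond the scatter), a step that rests on compound 1's limit and not on a number: the limit of > 200000 nM in this assay, at which 1 of the 4 values shown sits.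

The compounds shown do not tell whether the rise on the nitrogen follows the aromatic ring itself or the larger group, and a benzyl group or a propyl chain there would bear on that. They also leave open whether the same step holds when the oxygen carries methyl.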